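Notes on the acyl change from compound 1

The compounds below may be only part of what the source reports. "The series", "measured", "known", "first", "only" and "open" are said of these compounds alone.

For the measured compounds named here, compound 1 `COc1ccc(CN(C(=O)C(C)Br)c2cc(OC)c(OC)c(OC)c2)cc1O` holds the lower of the two numbers known in a functional assay on MGC-803 cells (Homo sapiens) for inhibition, read by MTT assay, with a stated time of 48 h; on this read-out lower numbers stand for stronger inhibition and higher numbers for weaker inhibition: compound 1 gives 120 nM, while compound 2 `COc1ccc(CNc2cc(OC)c(OC)c(OC)c2)cc1F` gives 39700 nM, a gap well beyond the scatter. Compound 3 `COc1ccc(CN(C(=O)/C=C/CBr)c2cc(OC)c(OC)c(OC)c2)cc1O` remains unmeasured; it differs from compound 1 by 3-bromoprop-1-en-1-yl in place of 1-bromoethyl on a carbonyl carbon. Going by the values given here, no step between measured compounds covers an acyl change of this kind, so there is no direct precedent for its direction. The step of a 1.2-fold lower number from compound 1 to compound 3 (0.08 log units; within the scatter) is expected to be small, within the scatter or at most slightly toward a lower number. Compound 3 is therefore estimated at 100 nM, with a range from 30 nM to 400 nM.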

Compound 3, half-maximal inhibitory concentration: 71 nM
For compound 3 the middle estimate is 1.4-fold (0.15 log units) above the measured one; measured number inside the range.
By their numbers in this assay, from the lowest: compounds 3 and 1 (each within the scatter of the next); then compound 2.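

In this assay, 3-bromoprop-1-en-1-yl in place of 1-bromoethyl on a carbonyl carbon gives a 1.7-fold lower number from compound 1 to compound 3 (0.23 log units; within the scatter). This acyl position therefore accepts a longer bromine-bearing group with a double bond outside aromatic rings, with no change beyond the scatter. No available evidence bears on why the two groups read alike.

Open, going by these compounds, is whether bromine is needed at all on this acyl group. A plain acetyl group, or a chlorine in place of bromine on the prop-1-en-1-yl chain, would address that question.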